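Methanesulfonamido in place of methoxy: outlook for compound 4

This account rests on a few compounds, and the source may have more. Where it says the series, first, only, none or still open, it means among the compounds named here.

Compound 1 `Cc1n[nH]cc1-c1cccc2c1CCC2c1ncc[nH]1` gives 3 nM in a functional assay on CHO cells for agonist activity at Alpha-1A adrenergic receptor (Homo sapiens), read by FLIPR and calcium flux; on this read-out lower numbers stand for an effect already at smaller amounts and higher numbers for an effect only at larger amounts of compound. Compound 2 `c1cc(-c2ccn[nH]2)c2c(c1)C(c1ncc[nH]1)CC2` gives 52 nM. Compound 3 `COc1cccc2c1CCC2c1ncc[nH]1` gives 32 nM, placing it at the higher end of the three numbers: one step is an 11-fold higher number from compound 1 to compound 3 (1.03 log units; beyond the scatter), beyond the scatter, whereas a 1.6-fold lower number from compound 2 to compound 3 (0.21 log units; within the scatter) lies within it. Compound 4 `CS(=O)(=O)Nc1cccc2c1CCC2c1ncc[nH]1` differs from compound 3 by methanesulfonamido in place of methoxy on an aromatic carbon. Within the data shown here, no measured step involves a methanesulfonamido; the two changes at this aromatic carbon, a 17-fold higher number from compound 1 to compound 2 (1.24 log units; beyond the scatter) and an 11-fold higher number from compound 1 to compound 3 (1.03 log units; beyond the scatter), concern pyrazolyl groups only, so they give no direct guide. With nothing pointing either way, the expected step is a 1.3-fold higher number from compound 3 to compound 4 (0.10 log units; within the scatter), not beyond the scatter. Compound 4 is therefore estimated at 40 nM, with a range from 10 nM to 160 nM.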

Compound 4, half-maximal effective concentration: 70 nM
Compound 4: middle estimate off by 1.8-fold (0.24 log units), on the low side, and the stated range covers the measured number.
By their numbers in this assay, from the lowest: compound 1; then compounds 3, 2 and 4 (each within the scatter of the next, the first and the last beyond it).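

At this aromatic carbon, methanesulfonamido in place of methoxy adds a reading for a group with no ring, in this assay (a 2.2-fold higher number from compound 3 to compound 4 (0.34 log units; beyond the scatter)). Against 1H-pyrazol-5-yl, methanesulfonamido is not told apart (a 1.3-fold higher number from compound 2 to compound 4 (0.13 log units; within the scatter)), while against 3-methyl-1H-pyrazol-4-yl the step is large (a 23-fold higher number from compound 1 to compound 4 (1.37 log units; beyond the scatter)), so compound 1 stays alone at the low end. Nothing available explains these steps.

On these data alone, an amine or a carboxylic acid on this carbon remains open. So does 1H-pyrazol-4-yl without its methyl, which would separate the methyl from the point of attachment.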